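Extending the chain on a dimethyl-substituted benzimidazole core

The compounds below may be only part of what the source reports. "The series", "measured", "known", "first", "only" and "open" are said of these compounds alone.

Of the compounds shown here, three with a shared core have been measured in an ADME assay on microsomes from liver for inhibition of cytochrome P450 2B1 (Rattus norvegicus); a higher number here means a weaker inhibitor, a lower number a stronger inhibitor. Compound 1 `Cc1nc2cc(Cl)c(Cl)cc2[nH]1` gives 81300 nM. Compound 2 `CCCc1nc2cc(C)c(C)cc2[nH]1`, which carries a propyl group, gives 110000 nM. Compound 3 `CCCCc1nc2cc(C)c(C)cc2[nH]1`, with a butyl group, gives 55000 nM. The three numbers sit close together: compound 3 stands at the low end of them, yet its gaps to compound 1 and to compound 2 both lie within the scatter of repeated measurements.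

Compound 4 `CCCCCCCc1nc2cc(C)c(C)cc2[nH]1` is not yet measured. It differs from compound 3 in one place: propyl in place of hydrogen on a saturated chain carbon, four bonds along the chain from an aromatic carbon. Read one bond further out, the same change turns the butyl chain of compound 3 into a heptyl chain.

Going by the values given here, only one measured step bears on this change, the lengthening of the chain by one carbon, a 2.0-fold lower number from compound 2 to compound 3 (0.30 log units; within the scatter). That step did not rise above the scatter. Adding three more carbons is a larger move in the same direction, so a modest downward drift is plausible for compound 4, but nothing in the data forces a step beyond the scatter. The expected step for compound 4 is a 1.8-fold lower number from compound 3 to compound 4 (0.26 log units; within the scatter). The estimated value for compound 4 in this assay is 30000 nM, with a range from 10000 nM to 90000 nM.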

Compound 4, half-maximal inhibitory concentration in the cytochrome P450 2B1 assay: 44700 nM
Compound 4: middle estimate off by 1.5-fold (0.17 log units), on the low side; low and high end bracket the measured number.
By their numbers in the cytochrome P450 2B1 assay, from the lowest: compounds 4, 3, 1 and 2 (each within the scatter of the next, the first and the last beyond it).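

In the cytochrome P450 2B1 assay, adding propyl at this position, four bonds along the chain from an aromatic carbon, gives a 1.2-fold lower number from compound 3 to compound 4 (0.09 log units; within the scatter), so turning the butyl chain into a heptyl chain leaves the reading within the scatter even though the added piece is larger than the single carbon of the earlier step. Taken over the whole span from propyl chain to heptyl chain, the same assay shows a 2.5-fold lower number from compound 2 to compound 4 (0.39 log units; beyond the scatter), the first step along this chain to clear the scatter, and only modestly. In a physicochemical assay for lipophilicity (on this read-out higher numbers stand for higher lipophilicity and lower numbers for lower lipophilicity), compound 3 gives 3.9 and compound 4 gives 5.4. Over the change from butyl to heptyl, the number in the cytochrome P450 2B1 assay stays within the scatter while the number in the physicochemical assay moves by a large amount, so a large measured rise in lipophilicity comes here with no readable change in inhibition: the measured partition coefficient of compound 3, 3.9, and of compound 4, 5.4, a number 1.50 log units higher (beyond the scatter)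

Going by these compounds, whether a still longer chain, or a chain ending in an amine or a carboxylic acid at this place, would move the inhibition number remains open. Compound 1 differs from the other compounds in more than one place, so the compounds shown cannot separate what its chlorine atoms do from what its short chain does.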